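This account rests on a few compounds, and the source may have more. Where it says the series, first, only, none or still open, it means among the compounds named here.

Measured in a functional assay on ECa-109 cells for inhibition, with ECa-109 cell line (Homo sapiens) as the target, read by sulforhodamine B assay; a lower number here means a stronger inhibitor, a higher number a weaker inhibitor:
- Compound 1 `O=C1C(Nc2ccccc2)=CC(=O)c2c1nc1n2[C@H]2OC[C@@H](O)[C@H]2OC1`: 3560 nM
- Compound 2 `O=C1C(N2CCCCC2)=CC(=O)c2c1nc1n2[C@H]2OC[C@@H](O)[C@H]2OC1`: > 8000 nM, a limit and not a number

Compound 2 has no exact position on this scale, and its result of > 8000 nM is only a limit, (the limit of > 8000 nM in this assay, at which 1 of the 2 values shown sits). Compound 3 `CCCN(CCC)C1=CC(=O)c2c(nc3n2[C@H]2OC[C@@H](O)[C@H]2OC3)C1=O` differs from it by dipropylamino in place of piperidin-1-yl on a double-bonded ring carbon, with dipropylamino in place of piperidin-1-yl on a double-bonded ring carbon. Among the compounds with values here, one measured step bears on this site: an at least 2.2-fold higher number from compound 1 to compound 2 (0.35 log units; beyond the scatter), where piperidin-1-yl replaced anilino. That step compares a different pair of groups, so it does not give the size of this change. Compound 3 is therefore expected to show no step beyond the scatter in this assay, in either direction, and another limit would not be surprising. The expected change is a number no higher from compound 2 to compound 3 (the limit leaves the size open). For compound 3 the estimate is 8000 nM, with an expected range from 3500 nM to 16000 nM.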

Compound 3, half-maximal inhibitory concentration: > 16000 nM
Compound 3 gave a limit, no number (the forecaster's own chance of this, stated with the estimate: 55%); middle value at least 2.0-fold (0.30 log units) away from the limit.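

In this assay the result for compound 3 is a limit and not a number: the limit of > 16000 nM in this assay, at which 1 of the 3 values shown sits. Dipropylamino in place of anilino gives an at least 4.4-fold higher number from compound 1 to compound 3 (0.65 log units; beyond the scatter), so an open-chain amine with no ring moves the result in the same direction as the ring amine piperidin-1-yl, which gave an at least 2.2-fold higher number from compound 1 to compound 2 (0.35 log units; beyond the scatter). The two limits leave the step between piperidin-1-yl and dipropylamino unreadable, so no order can be given for compound 2 and compound 3.

On these data alone, how far either amine actually lies from anilino remains open. Also open, as far as these compounds go, is how propylamino or benzylamino on this double-bonded ring carbon would compare with the anilino group of compound 1.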